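Replacing a halogenated styryl ring with 4-hydroxyphenyl

This account rests on a few compounds, and the source may have more. Where it says the series, first, only, none or still open, it means among the compounds named here.

- compound 1 `O=S(=O)(/C=C/c1ccc(Br)cc1)Cc1ccc(Nc2ncnc3ccccc23)cc1`: 42000 nM
- compound 2 `O=S(=O)(/C=C/c1ccc(F)cc1F)Cc1ccc(Nc2ncnc3ccccc23)cc1`: > 100000 nM
- compound 3 `O=S(=O)(/C=C/c1ccc(F)cc1Cl)Cc1ccc(Nc2ncnc3ccccc23)cc1`: 100000 nM

All three compounds were tested in a functional assay on PC-3 cells (Homo sapiens); on this read-out lower numbers stand for stronger inhibition of growth and higher numbers for weaker inhibition of growth. Compound 2 gives > 100000 nM, which is a limit and not a number. That leaves two true numbers, and compound 3 has the higher one at 100000 nM, so it inhibits growth more weakly than compound 1.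

Compound 4 `O=S(=O)(/C=C/c1ccc(O)cc1)Cc1ccc(Nc2ncnc3ccccc23)cc1` has not been measured yet. It carries 4-hydroxyphenyl in place of 2-chloro-4-fluorophenyl, on a double-bonded chain carbon bound to a double-bonded chain carbon: 4-hydroxyphenyl in place of 2-chloro-4-fluorophenyl on a double-bonded chain carbon bound to a double-bonded chain carbon.

The closest evidence is what happened when 4-bromophenyl was replaced. The first such change gave a 2.4-fold higher number from compound 1 to compound 3 (0.38 log units; beyond the scatter), and the second gave an at least 2.3-fold higher number from compound 1 to compound 2 (0.37 log units; beyond the scatter). Both point the same way, while a number no higher from compound 2 to compound 3 (the limit leaves the size open) cannot be sized. Compound 4 resembles compound 1 in carrying no chloro or fluoro group, and the step to compound 3 was modest, a 2.4-fold higher number from compound 1 to compound 3 (0.38 log units; beyond the scatter). A modest move back toward lower numbers in this assay is therefore expected. Within the data shown here, no measured compound carries a hydroxy group, and this expectation stays loose.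

The expected change is a 2.2-fold lower number from compound 3 to compound 4 (0.35 log units; beyond the scatter).

For compound 4 the estimated value is 45000 nM, with an expected range from 15000 nM to 100000 nM.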

Compound 4, concentration for 50% growth inhibition: 14000 nM
Compound 4: middle estimate off by 3.2-fold (0.51 log units), on the high side, outside the stated range (below it).
By their numbers in this assay, from the lowest: compound 4; then compound 1; then compound 3.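

Until now every ring at this place, on a double-bonded chain carbon bound to a double-bonded chain carbon, carried a halogen, and in this assay the first ring without one gives the lowest number of the series, with a 7.1-fold lower number from compound 3 to compound 4 (0.85 log units; beyond the scatter). Among these compounds, the single swap of hydroxy in place of bromo on an aromatic carbon also gives a 3.0-fold lower number from compound 1 to compound 4 (0.48 log units; beyond the scatter), so changing one group on this ring is enough to move the number beyond the scatter. Compared with the difluoro ring, the change reads as an at least 7.1-fold lower number from compound 2 to compound 4 (0.85 log units; beyond the scatter), but this size is only a lower bound, as compound 2 carries a limit and not a number: the limit of > 100000 nM in this assay, at which 1 of the 4 values shown sits.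

Going by these compounds, whether the hydroxy group's own hydrogen matters stays open, and a 4-methoxyphenyl or 4-aminophenyl ring in place of 4-hydroxyphenyl would help to separate that from simply having no halogen. The compounds shown also leave open whether a second hydroxy group on the ring would lower the number further, and whether the same swap would act in the same way on a different core.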